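Swapping Carboxyphenyl for Acetylphenyl on the Shared Core

The source may hold more compounds than are shown below. What is called first, only, known or untested is meant among the compounds shown, and "the series" means these compounds.

Compound 1, `N#CCC(=O)N/N=C1\C(=O)Nc2ccc(S(=O)(=O)N3CCOCC3)cc21`, gives 7530 nM in a functional assay on HepG2 cells (Homo sapiens) for cytotoxicity, read by sulforhodamine B assay, with a stated time of 24 h; a higher number here means a weaker inhibitor, a lower number a stronger inhibitor.
Compound 2, `O=C1Nc2ccc(S(=O)(=O)N3CCOCC3)cc2/C1=N/NS(=O)(=O)c1ccccc1`, gives 23900 nM.
Compound 3, `O=C1Nc2ccc(S(=O)(=O)N3CCOCC3)cc2/C1=N/c1ccc(C(=O)O)cc1`, gives 23100 nM.

Among these three numbers compound 3 holds the second highest. Compound 2 and compound 3 give numbers that sit within the usual scatter of each other, as the step of a 1.0-fold lower number from compound 2 to compound 3 (0.01 log units; within the scatter) shows. The one clear separation is from compound 1: a 3.1-fold higher number from compound 1 to compound 3 (0.49 log units; beyond the scatter).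

Compound 4, `CC(=O)c1cccc(/N=C2\C(=O)Nc3ccc(S(=O)(=O)N4CCOCC4)cc32)c1`, differs from compound 3 in one place: 3-acetylphenyl in place of 4-carboxyphenyl on a double-bonded nitrogen. Going by the values given here, no measured step exchanges one aromatic group for another on that double-bonded nitrogen. The two steps that end at compound 3 each replace a whole amino-linked substituent with the 4-carboxyphenyl group: a 3.1-fold higher number from compound 1 to compound 3 (0.49 log units; beyond the scatter) was a modest rise, while a 1.0-fold lower number from compound 2 to compound 3 (0.01 log units; within the scatter) stayed within the scatter. Among the compounds with values here, two quite different substituents at this position, in compound 2 and compound 3, therefore gave nearly the same number, and nothing among the measured compounds points to a strong effect from a change within the aromatic group itself. Compound 4 is thus expected to stay close to compound 3, with the step of a 1.2-fold lower number from compound 3 to compound 4 (0.06 log units; within the scatter) lying within the scatter. Compound 4 is estimated at 20000 nM, with a range from 8000 nM to 50000 nM.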

Compound 4, half-maximal inhibitory concentration: 28600 nM
Beside the measured number, compound 4's estimate is 1.4-fold (0.16 log units) below it; measured number inside the range.
By their numbers in this assay, from the lowest: compound 1; then compounds 3, 2 and 4 (each within the scatter of the next).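

In this assay, going by these compounds alone, a 1.2-fold higher number from compound 3 to compound 4 (0.09 log units; within the scatter) is the only step here that exchanges one aromatic group for another on the double-bonded nitrogen, and it stays within the scatter even though both the ring substituent and its place differ between 4-carboxyphenyl and 3-acetylphenyl. The 3-acetylphenyl group also cannot be told apart from the (phenylsulfonyl)amino group, as a 1.2-fold higher number from compound 2 to compound 4 (0.08 log units; within the scatter) shows, so compounds 2, 3 and 4 form a group of three with different substituents at this position and no separation among them. Only the ((cyanomethyl)carbonyl)amino group of compound 1 stands apart, as a 3.8-fold higher number from compound 1 to compound 4 (0.58 log units; beyond the scatter) shows, and nothing available explains either that separation or the agreement among the other three.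

The compounds shown leave open whether 3-carboxyphenyl or 4-acetylphenyl groups would also fall within the scatter of compound 3 and compound 4, which would test the ring substituent and its place one at a time. They also leave open whether the separation of compound 1 would persist with a longer chain ending in a nitrile, or with an amine in place of the nitrile.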